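Dropping the chloro group from compound 2

This account rests on a few compounds, and the source may have more. Where it says the series, first, only, none or still open, it means among the compounds named here.

Measured so far:
compound 1 `Clc1ccc(OCC2=NCCO2)cc1`: 30%
compound 2 `Cc1cc(OCC2=NCCO2)ccc1Cl`: 50%

In a toxicity assay on the whole organism with Rattus norvegicus as the target, at a dose of 100 mg/kg by the oral route (a higher number here means a stronger effect of the compound at the dose given, a lower number a weaker effect), compound 2 holds the highest of the two numbers. Within the data shown here, the only measured step, a number 20 percentage points higher from compound 1 to compound 2 (beyond the scatter), came with methyl in place of hydrogen on an aromatic carbon. Compound 3 `Cc1cccc(OCC2=NCCO2)c1` differs from compound 2 by hydrogen in place of chloro on an aromatic carbon. Among the measured compounds shown here, no measured step touches the chloro group, so the measured data give no direct guide for this change, and no step beyond the scatter is expected, a number 10 percentage points lower from compound 2 to compound 3 (within the scatter). Compound 3 is therefore estimated at 40%, within a range from 20% to 65%.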

Compound 3, a percentage reported as activity, at one dose (the size of the read-out at that dose, not a potency): 50%
Estimate against measurement, compound 3: 10 percentage points below; the range from low to high includes it.
By their numbers in this assay, from the lowest: compound 1; then compounds 2 and 3 (each within the scatter of the next).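

In this assay, putting hydrogen in place of chloro on an aromatic carbon, ortho to a methyl group, gives no change at the digits printed from compound 2 to compound 3 (within the scatter). Among these compounds, the earlier compounds showed only a step at the methyl position, so this is the first reading at the chloro position: with the methyl group present, the read-out at this dose does not depend on the chloro group. Nothing measured here explains this result.

Still open, from the compounds shown here alone, is whether the position would stay as unresponsive with an amine or a carboxylic acid there. Also open, going by these compounds, is whether removing chloro would give the same result without the methyl group.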